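The source may hold more compounds than are shown below. What is called first, only, known or untested is meant among the compounds shown, and "the series" means these compounds.

Series notes. Compound 1 `Cc1cc(=O)oc2cc(OCCCn3cc(CNC(=O)CCCCC4CCSS4)nn3)ccc12` gives 69.4% in a functional assay on PC-12 cells (Rattus norvegicus) for cytotoxicity, read by MTT assay, with stated times of 3 h and 2 h, tested at 10 uM; on this read-out lower numbers stand for a weaker effect and higher numbers for a stronger effect at the one concentration tested. For the measured compounds named here, compound 2 `CCOC(=O)c1cc2ccc(OCCCn3cc(CNC(=O)CCCCC4CCSS4)nn3)cc2oc1=O` gives 36.1% in this assay, the lowest of the two numbers so far; compound 1 stands higher by more than the usual scatter. Compound 3 `O=C(CCCCC1CCSS1)NCc1cn(CCCOc2ccc3cc(-c4ccc(Br)cc4)c(=O)oc3c2)nn1` has not been measured in this assay. Relative to compound 2 it differs in one place: 4-bromophenyl in place of ethoxycarbonyl on an aromatic carbon. Going by the values given here, no measured pair covers this change, so the expected step from compound 2 is uncertain; a small rise, within the usual scatter, is the working expectation: a number 7.9 percentage points higher from compound 2 to compound 3 (within the scatter). For compound 3 the estimated value in this assay is 44%, with a range from 25% to 68%.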

Compound 3, a percentage reported as activity, at one concentration (the size of the read-out at that concentration, not a potency): 63.3%
Compound 3: middle estimate off by 19.3 percentage points, on the low side, within the range that was stated.
By their numbers in this assay, from the lowest: compound 2; then compounds 3 and 1 (each within the scatter of the next).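

At this aromatic carbon, two atoms from the ring oxygen, the group carried matters in this assay: 4-bromophenyl in place of ethoxycarbonyl gives a number 27.2 percentage points higher from compound 2 to compound 3 (beyond the scatter). The position therefore accepts a six-membered aromatic ring of carbon only, with no loss of effect. No measurement at hand accounts for this step.

Still open, going by these compounds, is whether the step follows the aromatic ring, the bromine or the departure of ethoxycarbonyl; an unsubstituted phenyl, a carboxylic acid or an amine at this carbon would separate these readings. This single step says nothing about other positions on the shared core.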